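The source may report more compounds than this note shows. Statements on the series, on what has been measured and on what is new or still open speak of the compounds shown alone.

Two compounds have been measured in a functional assay for agonist activity at G protein-coupled receptor 88 (Homo sapiens), read by HTRF and cAMP accumulation; a higher number here means that more compound is needed for the effect, a lower number that less compound is needed:

Compound 1 `CC(C)C[C@H](N)CN(C(=O)[C@@H]1C[C@H]1c1ccccc1)c1ccc(C2=CCCCC2)cc1` gives 1200 nM.
Compound 2 `COc1ccc(-c2ccc(N(C[C@@H](N)CC(C)C)C(=O)[C@@H]3C[C@H]3c3ccccc3)cc2)cc1` gives 330 nM.

For the measured compounds named here, compound 2 stands lowest of the two numbers; its nearest neighbour is compound 1, and the only measured step, a 3.6-fold lower number from compound 1 to compound 2 (0.56 log units; beyond the scatter), separates them. That step swaps a cyclohexenyl ring for a methoxy-bearing benzene ring on the shared core.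

Compound 3 `COc1cccc(-c2ccc(N(C[C@@H](N)CC(C)C)C(=O)[C@@H]3C[C@H]3c3ccccc3)cc2)c1` is built from compound 2 by a different kind of change: 3-methoxyphenyl in place of 4-methoxyphenyl on an aromatic carbon. The same atoms are kept; only the point at which the methoxy group sits on the outer benzene ring moves.

Going by the values given here, no measured step bears on this kind of change. The step from compound 1 to compound 2 replaced one ring with another, and says nothing about shifting a substituent around a ring that is otherwise kept. The expectation must therefore rest on the view that such a shift usually alters the number by a modest amount, in either direction, and it is expected to be a 1.5-fold higher number from compound 2 to compound 3 (0.18 log units; within the scatter). Compound 3 is estimated at 500 nM, with a range from 180 nM to 1500 nM.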

Compound 3, half-maximal effective concentration: 1100 nM
Beside the measured number, compound 3's estimate is 2.2-fold (0.34 log units) below it, and the stated range covers the measured number.
By their numbers in this assay, from the lowest: compound 2; then compounds 3 and 1 (each within the scatter of the next).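

Moving the methoxy group around the outer benzene ring, with the same atoms kept, is not a neutral change in this assay: 3-methoxyphenyl in place of 4-methoxyphenyl gives a 3.3-fold higher number from compound 2 to compound 3 (0.52 log units; beyond the scatter), so where the group sits on this ring matters, not only that it is there. A methoxy-bearing benzene ring in place of the cyclohexenyl ring is also not enough on its own to lower the number, since 3-methoxyphenyl in place of cyclohex-1-en-1-yl gives a 1.1-fold lower number from compound 1 to compound 3 (0.04 log units; within the scatter), a step within the scatter, and only the 4-methoxyphenyl group of compound 2 stands apart from compound 1. Nothing measured here accounts for the difference between the two placements.

The compounds shown leave open what the methoxy group itself contributes, which a plain phenyl ring on the same core would help to settle. They also leave open whether other groups on the outer ring, such as a fluorine, a nitrile or an ethoxy group, would follow the same order between the two placements.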